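The source may report more compounds than this note shows. Statements on the series, on what has been measured and on what is new or still open speak of the compounds shown alone.

Measured in a functional assay on KBVIN cells (Homo sapiens) for cytotoxicity, read by MTT assay, with a stated time of 72 h; on this read-out higher numbers stand for an effect only at larger amounts of compound and lower numbers for an effect already at smaller amounts:
- compound 1 `CCc1cccc2c(O)c(-c3occ(C)c3C(=O)O)ccc12`: 7 ug/mL
- compound 2 `CCOC(=O)c1c(C)coc1-c1ccc2c(CC)cccc2c1OC`: 1.8 ug/mL
- compound 3 `CCc1cccc2c(OC(C)=O)c(-c3occ(C)c3COC(C)=O)ccc12`: > 10 ug/mL, a limit of the assay

Compound 2, at 1.8 ug/mL, has the lower of the two numbers, and the gap to compound 1 lies beyond the scatter. Compound 4 `CCc1cccc2c(OC)c(-c3occ(C)c3COC)ccc12` has methoxymethyl in place of ethoxycarbonyl on an aromatic carbon. Going by the values given here, no measured step isolates this change. Compound 1, which also lacks ethoxycarbonyl, gives 7 ug/mL, so a moderate move to a higher number in this assay is expected. Compound 3, also without ethoxycarbonyl, gives > 10 ug/mL, which is a limit. The expected change is a 2.5-fold higher number from compound 2 to compound 4 (0.40 log units; beyond the scatter). For compound 4 the estimated value is 4.5 ug/mL, with an expected range of 1.8 ug/mL to 10 ug/mL.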

Compound 4, concentration for half-maximal effect: 8.8 ug/mL
Estimate against measurement, compound 4: 2.0-fold (0.29 log units) below; the range from low to high includes it.
By their numbers in this assay, from the lowest: compound 2; then compounds 1 and 4 (each within the scatter of the next). At a limit, above all of these: compound 3.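

In this assay the swap of ethoxycarbonyl for methoxymethyl on this aromatic carbon now has a reading of its own, with a 4.9-fold higher number from compound 2 to compound 4 (0.69 log units; beyond the scatter) and the rest of the structure unchanged. The earlier compounds shown here differ from one another in more than one place, so they could not separate this position from the others. On this single pair, ethoxycarbonyl goes with the lower number.

Open, on these data alone, is how a carboxylic acid, an amide or a longer ester at this carbon would read with the rest of compound 2 kept. No measured property shown here bears on why the number moves.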